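The source may hold more compounds than are shown below. What is called first, only, known or untested is meant among the compounds shown, and "the series" means these compounds.

Going by the values given here, in an ADME assay on Caco-2 cells (Homo sapiens) for permeability, read by LC-MS, in the apical to basolateral direction, with a stated time of 60 min, at pH 6.5 (on this read-out higher numbers stand for higher permeability and lower numbers for lower permeability), compound 1 (`O=C(NCc1cc(Cl)ccc1-n1cnnn1)[C@@H]1[C@H]2C[C@H]2CN1C(=O)[C@H](O)c1ccccc1`) gives 12 10^-6 cm/s, the lower of the two numbers so far, and compound 2 (`CC(C)CC[C@@H](O)C(=O)N1N=CC[C@H]1C(=O)NCc1cc(Cl)ccc1-n1cnnn1`) gives 29 10^-6 cm/s, a gap beyond the usual scatter. Compound 3 (`O=C(NCc1cc(Cl)ccc1-n1cnnn1)[C@@H]1[C@H]2C[C@H]2CN1C(=O)[C@H](O)Cn1cccn1`) keeps the core of compound 1 but carries (1H-pyrazol-1-yl)methyl in place of phenyl on a saturated chain carbon bound to a carbonyl carbon and an oxygen on a saturated carbon. Among the compounds with values here, no measured pair shows this change, so only a modest fall is expected in this assay, possibly close to the scatter. The expected step is a 1.7-fold lower number from compound 1 to compound 3 (0.23 log units; within the scatter). For compound 3 the estimated value is 7 10^-6 cm/s, with an expected range of 3 10^-6 cm/s to 15 10^-6 cm/s.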

Compound 3, apparent permeability: 0.31 10^-6 cm/s
Compound 3: the middle estimate sits 23-fold (1.35 log units) above what was measured; measured number below the stated range.
By their numbers in this assay, from the lowest: compound 3; then compound 1; then compound 2.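

At this place, on a saturated chain carbon bound to a carbonyl carbon and an oxygen on a saturated carbon, this assay proves highly sensitive to the identity of the group: (1H-pyrazol-1-yl)methyl in place of phenyl gives a 39-fold lower number from compound 1 to compound 3 (1.59 log units; beyond the scatter). Both groups have 6 heavy atoms and no net charge, so these two counts do not separate them, whereas the hydrogen-bond acceptors go from 0 to 2. Nothing measured here gives a reason for the step. Still open, from the compounds shown here alone, is whether the step follows the ring nitrogens or the added chain carbon, which benzyl at this place would help to separate. Going by these compounds, whether the same change has a like effect on the core of compound 2 also remains open.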